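The source may report more compounds than this note shows. Statements on the series, on what has been measured and on what is new or still open speak of the compounds shown alone.

Compound 1, `COc1ccc(C(=O)/C=C/c2cc(-c3cc(OC)c(OC)c(OC)c3)n[nH]2)cc1OC`: 69%
Compound 2, `COc1ccc(C(=O)/C=C/c2cc(-c3cc(OC)c(OC)c(OC)c3)n[nH]2)cc1`: 86%

In a functional assay on OVCAR-8 cells (Homo sapiens) for cytotoxicity, read by sulforhodamine B assay, with a stated time of 48 h, tested at 1 uM (on this read-out lower numbers stand for a stronger effect and higher numbers for a weaker effect at the one concentration tested), compound 1 gives 69%, and compound 2 gives 86%. Within the data shown here, compound 2 therefore holds the highest of the two numbers, meaning the weaker effect at the single concentration tested, and its only neighbour is compound 1, separated by a number 17 percentage points higher from compound 1 to compound 2 (beyond the scatter), a change of a hydrogen in place of a methoxy on an aromatic carbon.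

Compound 3, `COc1cc(-c2cc(/C=C/C(=O)c3ccc(F)c(F)c3)[nH]n2)cc(OC)c1OC`, is not yet measured. It differs from compound 2 by 3,4-difluorophenyl in place of 4-methoxyphenyl on a carbonyl carbon. Among the measured compounds shown here, this change touches the same part of the molecule as the one measured step, but it swaps the whole group rather than removing a single methoxy, and nothing measured shows what fluorine does here. For the measured compounds named here, the one measured step was modest and went towards a weaker effect when the methoxy was lost, so a move of similar or smaller size in either direction, or none beyond the scatter, seems the fairest expectation; a number 2 percentage points lower from compound 2 to compound 3 (within the scatter) is what is estimated. Compound 3 is thus expected to give about 84%, within a range from 62% to 100%.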

Compound 3, a percentage reported as activity, at one concentration (the size of the read-out at that concentration, not a potency): 89%
Compound 3: middle estimate off by 5 percentage points, on the low side; the measured number falls inside the stated range.
By their numbers in this assay, from the lowest: compound 1; then compounds 2 and 3 (each within the scatter of the next).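

In this assay, replacing 4-methoxyphenyl with 3,4-difluorophenyl on the carbonyl carbon gives a number 3 percentage points higher from compound 2 to compound 3 (within the scatter), so this exchange of a whole ring leaves two compounds that this read-out cannot tell apart. Set against the 3,4-dimethoxyphenyl group, the same difluorinated ring gives a number 20 percentage points higher from compound 1 to compound 3 (beyond the scatter), which shows that two fluorines do not reproduce what the two methoxy groups give here and that, among these three rings, only the 3,4-dimethoxyphenyl of compound 1 stands apart, with the stronger effect at the one concentration tested. The data offer no independent measurement that would explain this difference between the rings.

The compounds shown leave open whether another ring on the carbonyl carbon, such as 3,4-dihydroxyphenyl, 3,4-dichlorophenyl or a phenyl carrying an amine, would match or surpass 3,4-dimethoxyphenyl. Also open, from the compounds shown here alone, is how these three compounds would compare across a range of concentrations, since a single-concentration read-out gives the size of an effect and not a potency.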